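Working notes: a new group on the carbonyl carbon

This account rests on a few compounds, and the source may have more. Where it says the series, first, only, none or still open, it means among the compounds named here.

In an ADME assay on CHO cells (Cricetulus griseus) for cytotoxicity (on this read-out higher numbers stand for weaker inhibition and lower numbers for stronger inhibition), compound 1 `Cc1cc(C(=O)Nc2cc(Nc3cnccn3)nc(-c3ccnc(N4CCNCC4)c3)c2)n(C)n1` reads > 20000 nM as a limit of the assay. Compound 2 `O=C(Cc1cccnc1)Nc1cc(Nc2cnccn2)nc(-c2ccnc(N3CCNCC3)c2)c1` reads > 20000 nM as a limit too, so it has no number, only a limit. The record so far is the limit of > 20000 nM in this assay, at which 2 of the 2 values shown sit, and nothing more. Compound 3 `O=C(Nc1cc(Nc2cnccn2)nc(-c2ccnc(N3CCNCC3)c2)c1)c1cncnc1` brings pyrimidin-5-yl in place of (pyridin-3-yl)methyl on a carbonyl carbon as its change from compound 2. Among the measured compounds shown here, the only measured step at this place is a step that the two limits leave unreadable from compound 1 to compound 2 and gives no size to carry over. No shift beyond the scatter is therefore expected in this assay and no direction is favoured. The estimated step is a number no higher from compound 2 to compound 3 (the limit leaves the size open) and no more than that is expected. Compound 3 is expected near 20000 nM with an estimated range from 9000 nM to 40000 nM and will most likely also return a limit.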

Compound 3, half-maximal inhibitory concentration: > 20000 nM
Compound 3: only a limit was reported; the forecaster's own chance of this, stated with the estimate: 80%; the middle value lies on the limit itself.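

Among the compounds shown here, no step among compound 1, compound 2 and compound 3 can be read in this assay, since each reports only a limit: the limit of > 20000 nM in this assay, at which 3 of the 3 values shown sit. The compounds shown leave open whether the group on the carbonyl carbon changes this read-out at all.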